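A few compounds are considered here, and "the series" means these few. Any claim that something is new, unique, unknown or untested is made for them only; others in the source may bear on it.

Of the compounds shown here, three built on one shared core have been measured. Compound 1 `COc1cc(Cl)cc(-c2nn(-c3cccc(NC(=O)Nc4ccc(Cl)c(C(F)(F)F)c4)c3)cc2-c2ccncc2)c1` gives 96% in a functional assay on NCI-H322M cells (Homo sapiens) for inhibition, read by sulforhodamine B assay, with a stated time of 48 h, tested at 0.01 uM; on this read-out higher numbers stand for a weaker effect at the one concentration tested and lower numbers for a stronger effect. Compound 2 `COc1cc(Cl)cc(-c2nn(-c3cccc(NC(=O)Nc4cc(C(F)(F)F)cc(C(F)(F)F)c4)c3)cc2-c2ccncc2)c1` gives 100%. Compound 3 `COc1cc(Cl)cc(-c2nn(-c3cccc(NC(=O)Nc4ccc(Cl)c(Cl)c4)c3)cc2-c2ccncc2)c1` gives 101%, and the three numbers all lie within the usual scatter of one another, so compound 3 stands among them without any real separation. Within the data shown here, the one recorded step between neighbours, a number 5 percentage points higher from compound 1 to compound 3 (within the scatter), also stayed within the scatter. Compound 4 `COc1cc(Cl)cc(-c2nn(-c3cccc(NC(=O)Nc4cccc(C(F)(F)F)c4)c3)cc2-c2ccncc2)c1` carries 3-(trifluoromethyl)phenyl in place of 3,4-dichlorophenyl on an amide-type nitrogen. This swap on the same outer ring resembles, in reverse, the change seen in that step, which was small. The expected step is therefore a number 3 percentage points lower from compound 3 to compound 4 (within the scatter), none beyond the scatter. Compound 4 is expected to give 98%, between 88% and 108%.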

Compound 4, a percentage reported as activity, at one concentration (the size of the read-out at that concentration, not a potency): 99%
Beside the measured number, compound 4's estimate is 1 percentage points below it, within the range that was stated.
By their numbers in this assay, from the lowest: compounds 1, 4, 2 and 3 (each within the scatter of the next).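

On the amide-type nitrogen, the outer ring now carries a single group, and this assay still shows no separation: swapping 3,4-dichlorophenyl for 3-(trifluoromethyl)phenyl gives a number 2 percentage points lower from compound 3 to compound 4 (within the scatter) and leaves the picture unchanged. Removing a group outright, rather than exchanging it, does no more: losing chloro gives a number 3 percentage points higher from compound 1 to compound 4 (within the scatter) and losing one trifluoromethyl gives a number 1 percentage points lower from compound 2 to compound 4 (within the scatter) on the same ring. Nothing measured here explains this flat result. Whether an amine or a carboxylic acid on this ring would shift the reading stays open, as does the behaviour of these compounds at other concentrations.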